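The source may report more compounds than this note shows. Statements on the series, on what has been measured and on what is new or still open speak of the compounds shown alone.

Measured so far in an ADME assay on L6 cells (Rattus norvegicus) for cytotoxicity, read by resazurin assay, with a stated time of 72 h; on this read-out lower numbers stand for stronger inhibition and higher numbers for weaker inhibition:

- compound 1, `OC(c1ccc(Cl)cc1)(c1ccc(Br)cc1)c1cncnc1`: 58700 nM
- compound 2, `OC(c1ccc(Cl)cc1)(c1ccc(C(F)(F)F)cc1)c1cncnc1`: 66800 nM
- compound 3, `OC(c1ccc(Cl)cc1)(c1cccnc1)c1ccccc1Br`: 55200 nM

Compound 2 differs from compound 1 by trifluoromethyl in place of bromo on an aromatic carbon. That change gives a 1.1-fold higher number from compound 1 to compound 2 (0.06 log units; within the scatter), so the two numbers are not distinguishable from each other. Compound 3 carries a different core; how the core of compound 3 differs from the core of compound 1 is not broken down here. The values of compound 3 and compound 1 lie within the scatter of each other, as do those of compound 3 and compound 2, so no ordering among the three measured compounds is claimed.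

Compound 4, `OC(c1ccc(Cl)cc1)(c1cccnc1)c1ccccc1C(F)(F)F`, has not yet been measured in this assay. It differs from compound 3 by trifluoromethyl in place of bromo on an aromatic carbon. This is the same kind of change as that from compound 1 to compound 2, not the same change: in compound 2 the entering group sits para to a large group, while in compound 4 it sits ortho to a large group. For the measured compounds named here, the only basis for an expectation is the pair compound 1 to compound 2, where the change left the number essentially unmoved, and the single value of compound 3.

Compound 4 is therefore expected to show a step of about a 1.1-fold higher number from compound 3 to compound 4 (0.04 log units; within the scatter) in this assay, a step expected to stay within the scatter because the measured pair gave a 1.1-fold higher number from compound 1 to compound 2 (0.06 log units; within the scatter). As far as these compounds go, the estimate for compound 4 is 60000 nM, with an expected range from 30000 nM to 120000 nM; the ortho placement is untested, so the range is kept wide.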

Compound 4, half-maximal inhibitory concentration: 59300 nM
Compound 4: middle estimate off by 1.0-fold (0.01 log units), on the high side, and the stated range covers the measured number.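

In this assay, trifluoromethyl in place of bromo on the core of compound 3, ortho to a large group, gives a 1.1-fold higher number from compound 3 to compound 4 (0.03 log units; within the scatter). Set beside the earlier pair, the change reads alike on the two cores: the same change on two cores in this assay, a 1.1-fold higher number (0.06 log units; within the scatter) from compound 1 to compound 2 and a 1.1-fold higher number (0.03 log units; within the scatter) from compound 3 to compound 4, 1.1-fold (0.03 log units) apart, within the scatter of two such steps. For the compounds shown here, this shows only that, in these two pairs, the exchange of bromo for trifluoromethyl leaves the number within the scatter on either core; neither step is a readable effect, so the agreement is between two steps that cannot be told from no step at all, and it does not show that a step of real size carries from one core to another, nor does it reach any core beyond these two or any other read-out.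

The compounds shown leave open whether any group at this place can move the number beyond the scatter, for instance an amine, a carboxylic acid or a longer alkyl chain in place of bromo or trifluoromethyl. Also open, as far as these compounds go, is whether the number depends on the chloro group or the hydroxyl that all four compounds share, since neither varies here.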